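Replacing the chloro chain with a hydroxy-dimethylamino chain

This account rests on a few compounds, and the source may have more. Where it says the series, first, only, none or still open, it means among the compounds named here.

Compound 1 `CCCCCCCCCCc1ccc(-c2noc(CC3CNC3)n2)cc1` in an assay on HeLa cells for inhibition of sphingosine-1-phosphate transporter SPNS2 (Mus musculus), read by LC-MS, tested at 2 uM; on this read-out lower numbers stand for less inhibition and higher numbers for more inhibition at the one concentration tested (going by the name of the read-out): 63%
Compound 2 `CCCCCCCCCCc1ccc(-c2noc([C@H]3CCC[C@@H](N)C3)n2)cc1` in this assay: 29%
Compound 3 `CCCCCCCCCCc1ccc(-c2noc(C(Cl)CCN)n2)cc1` in this assay: 5%

Compound 3 gives the lowest of the three numbers. The steps into it are both beyond the scatter: a number 58 percentage points lower from compound 1 to compound 3 (beyond the scatter) and a number 24 percentage points lower from compound 2 to compound 3 (beyond the scatter). Compound 4 `CCCCCCCCCCc1ccc(-c2noc(CC(O)CN(C)C)n2)cc1` is the next compound; the change is a group of 7 heavy atoms (5 carbon, 1 nitrogen, 1 oxygen; no ring) in place of a group of 5 heavy atoms (3 carbon, 1 nitrogen, 1 chlorine; no ring), on an aromatic carbon. Both measured steps concern the group that now leaves, and both were losses when it entered, the first large and the second modest, so undoing it may give back part of what was lost. Going by the values given here, no measured step brings in the entering group, so the size is uncertain. A modest rise is expected, a number 15 percentage points higher from compound 3 to compound 4 (beyond the scatter). Compound 4 is estimated at 20%, in the range 0% to 45%.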

Compound 4, a percentage reported as inhibition, at one concentration (the size of the read-out at that concentration, not a potency): 61%
The estimate for compound 4 lay 41 percentage points below the measured number; measured number outside the range, above it.
By their numbers in this assay, from the lowest: compound 3; then compound 2; then compounds 4 and 1 (each within the scatter of the next).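

In this assay, an open chain at this position does not by itself cost inhibition: 3-(dimethylamino)-2-hydroxypropyl brings a number 56 percentage points higher from compound 3 to compound 4 (beyond the scatter) and a number 32 percentage points higher from compound 2 to compound 4 (beyond the scatter), while the comparison with the ring-bearing group gives a number 2 percentage points lower from compound 1 to compound 4 (within the scatter). Among these compounds, then, a four-membered non-aromatic ring is not needed here. No evidence at hand accounts for this result. Still open, going by these compounds, is whether the hydroxy group, the dimethylamino group or both carry the gain, as they enter together. A methoxy group in place of the hydroxy, or a primary amine in place of the dimethylamino group, would separate them.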